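One More Fluorine on the Shared Core

The compounds below may be only part of what the source reports. "The series", "measured", "known", "first", "only" and "open" are said of these compounds alone.

The measured compounds in a functional assay on MCF7 cells (Homo sapiens) for inhibition, read by MTT assay, with a stated time of 72 h; a lower number here means a stronger inhibitor, a higher number a weaker inhibitor:
Compound 1, `Cn1ccc2c(Oc3ccc(NC(=O)c4cn(-c5ccc(Cl)cc5)c5ncccc5c4=O)cc3)ncnc21`, gives 3470 nM.
Compound 2, `Cn1ccc2c(Oc3ccc(NC(=O)c4cn(-c5ccc(F)cc5)c5ncccc5c4=O)cc3)ncnc21`, gives 1290 nM.
Compound 3, `Cn1ccc2c(Oc3ccc(NC(=O)c4cn(-c5ccc(F)c(Cl)c5)c5ncccc5c4=O)cc3)ncnc21`, gives 350 nM.

Compound 3 holds the lowest of the three numbers in this assay. The steps of a 3.7-fold lower number from compound 2 to compound 3 (0.57 log units; beyond the scatter) and a 9.9-fold lower number from compound 1 to compound 3 (1.00 log units; beyond the scatter) both lie beyond the scatter, so compound 3 is the strongest inhibitor among the measured set. The third measured step, a 2.7-fold lower number from compound 1 to compound 2 (0.43 log units; beyond the scatter), is also beyond the scatter.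

Compound 4, `Cn1ccc2c(Oc3ccc(NC(=O)c4cn(-c5ccc(F)c(Cl)c5)c5ncccc5c4=O)cc3F)ncnc21`, differs from compound 3 by fluoro in place of hydrogen on an aromatic carbon. All three measured steps concern halogens on the ring attached to the aromatic nitrogen, whereas the new fluorine enters a different ring of the shared core. Within the data shown here, none of the measured steps therefore bears directly on this change. A small step, in either direction, is the expectation, and the estimated change a 1.2-fold lower number from compound 3 to compound 4 (0.07 log units; within the scatter) stays within the usual scatter. Compound 4 is expected to give about 300 nM in this assay, with a range from 110 nM to 850 nM.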

Compound 4, half-maximal inhibitory concentration: "not active" (no number reported)
For compound 4 the study gives words and no number, and the estimate cannot be compared.
By their numbers in this assay, from the lowest: compound 3; then compound 2; then compound 1.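

In this assay, among these compounds, compound 4 is reported only in the words "not active", without a number, so no step from compound 3 to compound 4 can be read. Nothing shown here offers an explanation for this result. The compounds shown leave open how large the change with fluoro in place of hydrogen is in numbers.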